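The source may hold more compounds than are shown below. What is called first, only, known or untested is meant among the compounds shown, and "the series" means these compounds.

Measured compounds:
compound 1 `COc1cc(Cl)cc(-c2nn(-c3cccc(NC(=O)c4ccc(Cl)c(Cl)c4)c3)cc2-c2ccncc2)c1`: 88.5%
compound 2 `COc1cc(Cl)cc(-c2nn(-c3cccc(NC(=O)c4cccc(C(F)(F)F)c4)c3)cc2-c2ccncc2)c1`: 83.8%
compound 3 `O=C(Nc1cccc(-n2cc(-c3ccncc3)c(-c3cc(O)cc(Cl)c3)n2)c1)c1cc(C(F)(F)F)cc(C(F)(F)F)c1`: 62.1%

In a functional assay on DU-145 cells (Homo sapiens) for inhibition, read by sulforhodamine B assay, with a stated time of 48 h, tested at 10 uM (a higher number here means a weaker effect of the compound at the concentration tested, a lower number a stronger effect), compound 3 stands lowest of the three, the nearest number being that of compound 2 and the furthest that of compound 1, both beyond the scatter. Compound 4 `COc1cc(Cl)cc(-c2nn(-c3cccc(NC(=O)c4cc(C(F)(F)F)cc(C(F)(F)F)c4)c3)cc2-c2ccncc2)c1` differs from compound 3 in one place: methyl in place of hydrogen on an oxygen on an aromatic ring. No measured step changes this oxygen; the only step shown, a number 4.7 percentage points lower from compound 1 to compound 2 (within the scatter), concerns a different place on the amide and lies within the scatter, so it gives no direct guide. With compounds 1 and 2, which carry the methoxy, sitting higher than compound 3, a modest upward movement is expected but cannot be resolved from the scatter; the step of a number 7.9 percentage points higher from compound 3 to compound 4 (within the scatter) is therefore estimated as small. Compound 4 is expected at 70%, in the range 52% to 88%.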

Compound 4, a percentage reported as activity, at one concentration (the size of the read-out at that concentration, not a potency): 78.2%
Compound 4: the middle estimate sits 8.2 percentage points below what was measured; the range from low to high includes it.
By their numbers in this assay, from the lowest: compound 3; then compounds 4, 2 and 1 (each within the scatter of the next, the first and the last beyond it).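

In this assay the oxygen on the aromatic ring now has a measured step: going from hydroxy to methoxy gives a number 16.1 percentage points higher from compound 3 to compound 4 (beyond the scatter), so the stronger effect at the concentration tested goes with the free hydroxy. Trifluoromethyl in place of hydrogen on an aromatic carbon gives a number 5.6 percentage points lower from compound 2 to compound 4 (within the scatter), so this change cannot be read as an effect. No evidence is available that explains the hydroxy result. Still open, on these data alone, is whether an amine or an ethoxy group in place of the hydroxy would keep the effect of compound 3. Also open, as far as these compounds go, is whether hydroxy in place of methoxy would give a similar step with the amides of compound 1 and compound 2.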